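The source may hold more compounds than are shown below. What is called first, only, known or untested is meant among the compounds shown, and "the series" means these compounds.

Measured compounds in the series:
- Compound 1, `COc1cc2c(Oc3ccc(NC(=O)c4cc(-c5ccccc5)nc5ccccc45)cc3F)ccnc2cc1OCCCN1CCCCC1`, 110 nM
- Compound 2, `COc1cc2c(Oc3ccc(NC(=O)c4cc(-c5cccc(Cl)c5)nc5ccccc45)cc3F)ccnc2cc1OCCCN1CCCCC1`, 11 nM
- Compound 3, `COc1cc2c(Oc3ccc(NC(=O)c4cc(-c5cccc(Cl)c5)nc5ccccc45)cc3F)ccnc2cc1OCCCN1CCC(C)CC1`, 65 nM

In a functional assay on NCI-H460 cells (Homo sapiens) for cytotoxicity, read by MTT assay, with a stated time of 72 h (on this read-out higher numbers stand for weaker inhibition and lower numbers for stronger inhibition), compound 3 stands second highest of the three numbers; its gap to compound 1 lies within the scatter, while a 5.9-fold higher number from compound 2 to compound 3 (0.77 log units; beyond the scatter) is beyond it. Compound 4, `COc1ccc(-c2cc(C(=O)Nc3ccc(Oc4ccnc5cc(OCCCN6CCC(C)CC6)c(OC)cc45)c(F)c3)c3ccccc3n2)cc1`, has not been measured; it differs from compound 3 by 4-methoxyphenyl in place of 3-chlorophenyl on an aromatic carbon. Within the data shown here, no measured step tests this exchange directly. Among the measured compounds shown here, the only step at the same aromatic carbon is a 10-fold lower number from compound 1 to compound 2 (1.00 log units; beyond the scatter), a chloro entering for hydrogen; here the chlorine leaves again, and a methoxy group on a different ring carbon enters, for which nothing measured exists. The methyl on the saturated ring, seen in a 5.9-fold higher number from compound 2 to compound 3 (0.77 log units; beyond the scatter), is kept. Losing the chloro is therefore expected to cost part of what it brought, giving a modest rise in the number, so a 2.3-fold higher number from compound 3 to compound 4 (0.36 log units; beyond the scatter) is expected. Compound 4 is estimated at 150 nM, with a range from 50 nM to 500 nM.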

Compound 4, half-maximal inhibitory concentration: 110 nM
Compound 4: the middle estimate sits 1.4-fold (0.13 log units) above what was measured, within the range that was stated.
By their numbers in this assay, from the lowest: compound 2; then compounds 3, 1 and 4 (each within the scatter of the next).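

At the aromatic carbon next to the ring nitrogen, 4-methoxyphenyl in place of 3-chlorophenyl gives a 1.7-fold higher number from compound 3 to compound 4 (0.23 log units; within the scatter) in this assay on the background with the methyl on the saturated ring, so this exchange is not resolved from the scatter. The earlier chloro step (a 10-fold lower number from compound 1 to compound 2 (1.00 log units; beyond the scatter)) was beyond the scatter, but it had a different background and placed chloro for hydrogen, whereas here a methoxy group enters on a different ring carbon as the chlorine leaves. Nothing available explains how this exchange reads.

The compounds shown leave open how the loss of chloro and the gain of methoxy each contribute, since no plain phenyl is shown with the methyl-bearing saturated ring. They also leave open how an amine or a carboxylic acid on this phenyl ring would read.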